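The source may report more compounds than this note shows. Statements on the series, on what has been measured and on what is new or still open speak of the compounds shown alone.

Of the compounds shown here, two with the shared core have been measured so far. In a functional assay on MCF7 cells (Homo sapiens) for cytotoxicity, read by sulforhodamine B assay, with a stated time of 48 h (on this read-out higher numbers stand for weaker inhibition and lower numbers for stronger inhibition), compound 1 `O=C(c1ccc2nc(NC(=O)C(F)(F)F)cn2c1)c1ccc(C(F)(F)F)cc1F` gives 24900 nM, while compound 2 `Cc1ccc(F)c(C(=O)c2ccc3nc(NC(=O)C(F)(F)F)cn3c2)c1` gives 50800 nM. Compound 2 therefore holds the higher of the two numbers, meaning the weaker inhibition, and its gap to compound 1 lies beyond the usual scatter. Neither compound shows strong cytotoxicity on these numbers.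

The next compound, compound 3 `O=C(c1ccc2nc(NC(=O)C(F)(F)F)cn2c1)c1cc(C(F)(F)F)ccc1F`, departs from compound 2 at one place: trifluoromethyl in place of methyl on an aromatic carbon. This puts trifluoromethyl in place of methyl on an aromatic carbon, meta to a large group and para to a fluoro group. For the measured compounds named here, no measured pair isolates this exchange, so the expectation rests on thin evidence. Going by the values given here, the only guide is that compound 1, which also carries a trifluoromethyl group, gives 24900 nM. A small move towards lower numbers in this assay is therefore expected, and it may stay within the scatter. The estimated change is a 1.6-fold lower number from compound 2 to compound 3 (0.20 log units; within the scatter). For compound 3 the estimated value is 32000 nM, with an expected range from 13000 nM to 80000 nM.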

Compound 3, half-maximal inhibitory concentration: 10700 nM
The estimate for compound 3 lay 3.0-fold (0.48 log units) above the measured number, outside the stated range (below it).
By their numbers in this assay, from the lowest: compound 3; then compound 1; then compound 2.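

Exchanging methyl for trifluoromethyl on this aromatic carbon, meta to a large group and para to a fluoro group, gives in this assay a 4.7-fold lower number from compound 2 to compound 3 (0.68 log units; beyond the scatter) and so shows that this position responds to the change, with the number moving towards stronger inhibition. For the compounds shown here, this is the only measured step that isolates a single exchange, and its size lies beyond the scatter even though the counted hydrogen-bond donors, hydrogen-bond acceptors, rings and net charge all stay the same. Nothing available explains why the number falls with this exchange.

This one step does not tell whether the position would respond in the same direction to a chloro group, a methoxy group, an amine, a carboxylic acid or a longer chain. It also leaves open whether the same exchange of methyl for trifluoromethyl would give a step of similar size on another aromatic carbon of this ring, or on a ring without the fluoro group.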